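This account rests on a few compounds, and the source may have more. Where it says the series, first, only, none or still open, it means among the compounds named here.

Compound 1 `CCCCNc1nc(N)nc2c1CN(Cc1ccccc1Cl)CC2` sits in the middle of the three compounds measured in an assay on HEK293 cells for agonist activity at Toll-like receptor 8 (Homo sapiens), read by a luciferase reporter, with a stated time of 6 h (a higher number here means that more compound is needed for the effect, a lower number that less compound is needed), where compound 1 gives 0.05 uM. Compound 2 `CCCCNc1nc(N)nc2c1CN(Cc1cccc(OC)c1Cl)CC2` gives 0.04 uM in this assay, and the change a 1.3-fold lower number from compound 1 to compound 2 (0.10 log units; within the scatter) stays within the scatter. Compound 3 `CCCCNc1nc(N)nc2c1CN(Cc1c(Cl)cccc1Cl)CC2` gives 0.14 uM, so that a 2.8-fold higher number from compound 1 to compound 3 (0.45 log units; beyond the scatter) is a modest shift beyond the scatter. Compound 4 `CCCCNc1nc(N)nc2c1CN(C(=O)c1ccncc1)CC2` differs from compound 1 by (pyridin-4-yl)carbonyl in place of 2-chlorobenzyl on an amine nitrogen in a ring. Both measured steps concern only a substituent added to the aromatic ring of the 2-chlorobenzyl group while that group itself remains; neither step touches the kind of change by which compound 4 departs from compound 1, in which the whole 2-chlorobenzyl group leaves and a (pyridin-4-yl)carbonyl group enters on the amine nitrogen in the ring. The data therefore give no direct guide, and the step is expected to be larger than any of the measured ones, in the direction of a higher number. For compound 4 the expected step is a 40-fold higher number from compound 1 to compound 4 (1.60 log units; beyond the scatter), and its estimated value in this assay is 2 uM, within a range from 0.3 uM to 20 uM.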

Compound 4, minimum effective concentration: > 25 uM
Compound 4: only a limit was reported; the forecaster's own chance of this, stated with the estimate: 25%; middle value at least 12-fold (1.09 log units) away from the limit.
By their numbers in this assay, from the lowest: compounds 2 and 1 (each within the scatter of the next); then compound 3. At a limit, above all of these: compound 4.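

Compound 4 gives only a limit in this assay, not a number: the limit of > 25 uM in this assay, at which 1 of the 4 values shown sits. Going by these compounds alone, exchanging the whole group on the amine nitrogen in a ring brings an at least 500-fold higher number from compound 1 to compound 4 (2.69 log units; beyond the scatter), a large step, whereas the earlier steps, which kept the 2-chlorobenzyl group and only added to its aromatic ring, were far smaller. The two groups have the same count of 8 heavy atoms and each holds one six-membered aromatic ring, so a matching atom count and a ring of that size on this nitrogen do not by themselves preserve the effect in this assay.

The compounds shown leave open which part of the change matters, the carbonyl or the ring nitrogen of the pyridine. A benzoyl group or a pyridin-4-ylmethyl group on the same nitrogen would separate the two.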